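Purine acetamide series: side-chain swap in the tail flick test

The source may hold more compounds than are shown below. What is called first, only, known or untested is meant among the compounds shown, and "the series" means these compounds.

Measured compounds:
compound 1, `CC(C)[C@H](NC(=O)CN(c1nc(Cl)nc2[nH]cnc12)C1CC1)C(=O)O`: 7.86%
compound 2, `CSCC[C@H](NC(=O)CN(c1nc(Cl)nc2[nH]cnc12)C1CC1)C(=O)O`: 4.14%
compound 3, `CSCC[C@H](NC(=O)CN(c1ncnc2c1ncn2C1CCCCO1)C1CC1)C(=O)OCc1ccccc1`: 17.5%

In a functional assay on the whole organism (Tail, strain ICR) with Mus musculus as the target, in the tail flick test, with a stated time of 150 min, at a dose of 25 umol/kg by the oral route (on this read-out higher numbers stand for a stronger effect at the one dose given and lower numbers for a weaker effect), compound 2 gives 4.14% and compound 1 gives 7.86%. The two differ by isopropyl in place of 2-(methylsulfanyl)ethyl on a saturated chain carbon bound to an amide-type nitrogen and a carbonyl carbon, and the step is a number 3.7 percentage points higher from compound 2 to compound 1 (within the scatter). Compound 3 carries a different core; that difference between the two cores is not broken down here, and its value is simply the highest of the three, with compound 1 within the scatter and compound 2 beyond it.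

Compound 4, `CC(C)[C@H](NC(=O)CN(c1ncnc2c1ncn2C1CCCCO1)C1CC1)C(=O)OCc1ccccc1`, is not yet measured. It differs from compound 3 by isopropyl in place of 2-(methylsulfanyl)ethyl on a saturated chain carbon bound to an amide-type nitrogen and a carbonyl carbon, at a place described in the same words as for the earlier pair, so it is the same kind of change. Because the earlier step of a number 3.7 percentage points higher from compound 2 to compound 1 (within the scatter) was within the scatter, the step from compound 3 to compound 4 in this assay is expected to be small, a number 3.5 percentage points higher from compound 3 to compound 4 (within the scatter). Compound 4 is therefore estimated at 21%, between 8% and 35%.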

Compound 4, a percentage reported as activity, at one dose (the size of the read-out at that dose, not a potency): 21.1%
Compound 4: the middle estimate sits 0.1 percentage points below what was measured; the range from low to high includes it.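

In this assay, isopropyl in place of 2-(methylsulfanyl)ethyl gives a number 3.6 percentage points higher from compound 3 to compound 4 (within the scatter). Set beside the earlier pair, the change reads alike on both cores: the same change on two cores in this assay, a number 3.7 percentage points higher (within the scatter) from compound 2 to compound 1 and a number 3.6 percentage points higher (within the scatter) from compound 3 to compound 4, 0.1 percentage points apart, within the scatter of two such steps. This shows that the change carries from one core to the other with no detectable difference in its step, but as both steps lie within the scatter, it does not show that isopropyl gains anything over 2-(methylsulfanyl)ethyl on either core, nor does it extend to any further core.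

Going by these compounds, what a longer chain or an amine would give on a saturated chain carbon bound to an amide-type nitrogen and a carbonyl carbon stays open. So does the effect of a benzyl ester on the core of compound 1.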